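This account rests on a few compounds, and the source may have more. Where it says the series, first, only, none or still open, it means among the compounds named here.

Measured compounds in a functional assay on K562 cells (Homo sapiens), read by MTT assay, with a stated time of 72 h; a higher number here means a weaker inhibitor, a lower number a stronger inhibitor:

compound 1, `COc1ncnc2c1c(-c1ccsc1)cn2[C@@H]1O[C@H](CO)[C@@H](O)[C@H]1O`, gives 90 nM
compound 2, `CN(C)c1ncnc2c1c(-c1ccsc1)cn2[C@@H]1O[C@H](CO)[C@@H](O)[C@H]1O`, gives 530 nM
compound 3, `COc1ncnc2c1c(-c1ccoc1)cn2[C@@H]1O[C@H](CO)[C@@H](O)[C@H]1O`, gives 190 nM

Compound 1 and compound 2 differ in one place: dimethylamino in place of methoxy on an aromatic carbon. That change gave a 5.9-fold higher number from compound 1 to compound 2 (0.77 log units; beyond the scatter). Compound 3 differs from compound 1 in another place: furan-3-yl in place of thiophen-3-yl on an aromatic carbon, a change that gave a 2.1-fold higher number from compound 1 to compound 3 (0.32 log units; beyond the scatter). Compound 4, `CN(C)c1ncnc2c1c(-c1ccoc1)cn2[C@@H]1O[C@H](CO)[C@@H](O)[C@H]1O`, has not been measured in this assay. It differs from compound 3 by dimethylamino in place of methoxy on an aromatic carbon, the same change as that between compound 1 and compound 2, made on the core of compound 3 rather than on the core of compound 1.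

Within the data shown here, only one earlier example of this change exists, so the expectation rests on it alone. The step from compound 3 to compound 4 is expected to be about as large as the earlier one, a 5.8-fold higher number from compound 3 to compound 4 (0.76 log units; beyond the scatter), because compound 1 to compound 2 showed a 5.9-fold higher number from compound 1 to compound 2 (0.77 log units; beyond the scatter). Starting from compound 3 at 190 nM, compound 4 is therefore estimated at 1100 nM, within a range from 400 nM to 3000 nM.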

Compound 4, half-maximal inhibitory concentration: 1540 nM
Estimate against measurement, compound 4: 1.4-fold (0.15 log units) below; the range from low to high includes it.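

In this assay, dimethylamino in place of methoxy gave an 8.1-fold higher number from compound 3 to compound 4 (0.91 log units; beyond the scatter), and this step matches the one seen earlier on the other core: the same change on two cores in this assay, a 5.9-fold higher number (0.77 log units; beyond the scatter) from compound 1 to compound 2 and an 8.1-fold higher number (0.91 log units; beyond the scatter) from compound 3 to compound 4, 1.4-fold (0.14 log units) apart, within the scatter of two such steps. Furan-3-yl in place of thiophen-3-yl likewise gave a 2.9-fold higher number from compound 2 to compound 4 (0.46 log units; beyond the scatter), and this step also matches its earlier counterpart: the same change on two cores in this assay, a 2.1-fold higher number (0.32 log units; beyond the scatter) from compound 1 to compound 3 and a 2.9-fold higher number (0.46 log units; beyond the scatter) from compound 2 to compound 4, 1.4-fold (0.14 log units) apart, within the scatter of two such steps. Across these four compounds, each change therefore kept its size whichever group sat elsewhere on the shared core, but that rests on only two examples of each change, so it does not show that the same would hold on other cores, and it does not explain why either change raises the number.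

The compounds shown leave open whether the same step sizes would appear with a primary amine or an ethoxy group in place of methoxy, or with a phenyl ring in place of thiophen-3-yl. They also leave open whether these steps would hold in any cell line beyond the K562 cells of this assay.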